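A few compounds are considered here, and "the series" means these few. Any claim that something is new, unique, unknown or untested is made for them only; others in the source may bear on it.

Measured so far:
compound 1 `CCCCCCCCCCS(=O)(=O)/C=C/c1ccc(O)c(O)c1` — 6800 nM
compound 2 `C=CCCCCCS(=O)(=O)/C=C/c1ccc(O)c(O)c1` — 7100 nM
compound 3 `O=S(=O)(/C=C/c1ccc(O)c(O)c1)CCCc1ccccc1` — 11500 nM

In a functional assay, read by fluorescence and spectrophotometry, with a stated time of 1 h (on this read-out higher numbers stand for an effect only at larger amounts of compound and lower numbers for an effect already at smaller amounts), compound 1 gives 6800 nM, the lowest of the three numbers, yet the other two stand close: compound 2 gives 7100 nM and compound 3 gives 11500 nM, and both steps away from compound 1 fall within the scatter, a 1.0-fold higher number from compound 1 to compound 2 (0.02 log units; within the scatter) and a 1.7-fold higher number from compound 1 to compound 3 (0.23 log units; within the scatter). Between the other two the picture is the same, a 1.6-fold higher number from compound 2 to compound 3 (0.21 log units; within the scatter).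

Compound 4 `CCCCCCCCS(=O)(=O)/C=C/c1ccc(O)c(O)c1` has not yet been measured. It differs from compound 1 in this way: hydrogen in place of ethyl on a saturated chain carbon, eight bonds along the chain from a sulfonyl sulfur. Among the measured compounds shown here, the steps that bear on it are those that reshape the saturated chain beyond the sulfonyl sulfur while keeping the rest of the molecule untouched, and all of them stayed within the scatter. Shortening the chain by ethyl is therefore expected to give no step beyond the scatter in this assay, if anything a slightly higher number. Compound 4 is expected to give 8000 nM, with a range from 4500 nM to 14000 nM. The expected step is a 1.2-fold higher number from compound 1 to compound 4 (0.07 log units; within the scatter).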

Compound 4, half-maximal effective concentration: 6400 nM
Estimate against measurement, compound 4: 1.3-fold (0.10 log units) above, within the range that was stated.
By their numbers in this assay, from the lowest: compounds 4, 1, 2 and 3 (each within the scatter of the next).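

In this assay, taking away ethyl on a saturated chain carbon, eight bonds along the chain from a sulfonyl sulfur, gives a step that stays within the scatter (a 1.1-fold lower number from compound 1 to compound 4 (0.03 log units; within the scatter)), so a shortening of the fully saturated chain now joins the earlier chain changes in moving nothing beyond it. The saturated chain of compound 4 also stands within the scatter of the chain ends carrying vinyl (a 1.1-fold lower number from compound 2 to compound 4 (0.05 log units; within the scatter)) and phenyl (a 1.8-fold lower number from compound 3 to compound 4 (0.25 log units; within the scatter)), and across these four compounds no chain change shows a step beyond the scatter. No measurement is at hand that would account for this flat picture.

From the compounds shown here alone, whether a much longer chain, or a chain carrying an amine or a carboxylic acid, would give a step beyond the scatter in this assay stays open. Going by these compounds, all four compounds carry the shared core unchanged, and what a change there would do is equally open.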